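Anilinopyrimidine series: exchange of the aniline substituent

The source may report more compounds than this note shows. Statements on the series, on what has been measured and on what is new or still open speak of the compounds shown alone.

Measured so far in a functional assay for inhibition, with Homo sapiens as the target; a lower number here means a stronger inhibitor, a higher number a weaker inhibitor:
compound 1 `c1cncc(-c2ccnc(Nc3ccc(-n4ccnc4)cc3)n2)c1` gives 1300 nM
compound 2 `c1csc(-c2ccnc(Nc3ccc(-n4ccnc4)cc3)n2)c1` gives 4300 nM
compound 3 `c1ccc(-c2ccnc(Nc3ccc(-n4ccnc4)cc3)n2)nc1` gives 1400 nM

Compound 1 holds the lowest number of the three in this assay; compound 3 sits nearest, with a 1.1-fold higher number from compound 1 to compound 3 (0.03 log units; within the scatter), which is within the scatter, so the two cannot be ordered. Compound 2 lies furthest, with a 3.3-fold higher number from compound 1 to compound 2 (0.52 log units; beyond the scatter), and the same gap reappears as a 3.1-fold lower number from compound 2 to compound 3 (0.49 log units; beyond the scatter). Both of these steps concern the heteroaryl on the shared core and are modest in size.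

Compound 4 `CNc1ccc(Nc2nccc(-c3cccnc3)n2)cc1` is not yet measured. It differs from compound 1 in a different part of the molecule: methylamino in place of 1H-imidazol-1-yl on an aromatic carbon. Within the data shown here, no measured step touches this position; the steps from compound 1 to compound 2 and to compound 3 vary only the heteroaryl, so they give no direct guide. They do show that single-ring exchanges in this series have moved this assay only modestly. For compound 4 a change of similar or smaller size is expected, with the direction uncertain and a slight lean toward a higher number, so the estimate is a 1.9-fold higher number from compound 1 to compound 4 (0.28 log units; within the scatter). Compound 4 is therefore estimated at 2500 nM in this assay, within a range of 600 nM to 10000 nM.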

Compound 4, half-maximal inhibitory concentration: 2100 nM
Estimate against measurement, compound 4: 1.2-fold (0.08 log units) above, within the range that was stated.
By their numbers in this assay, from the lowest: compounds 1, 3 and 4 (each within the scatter of the next); then compound 2.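

In this assay, among these compounds, the aniline substituent itself changes for the first time, and the exchange gives a 1.6-fold higher number from compound 1 to compound 4 (0.21 log units; within the scatter) without leaving the scatter, so compound 1 and compound 4 cannot be ordered. At this position, para to a large group, the five-membered aromatic ring of 1H-imidazol-1-yl can therefore give way to methylamino, which has no ring, fewer heavy atoms and a hydrogen-bond donor that the imidazole lacks, with no readable change in this assay. No supporting data bear on this result, so the tolerance is recorded only as an observation.

Open, as far as these compounds go, is how a dimethylamino group, a morpholine ring or a carboxylic acid on the same aromatic carbon would compare with methylamino and 1H-imidazol-1-yl, and whether any such group would produce a step beyond the scatter. Among the compounds shown here, also open is whether methylamino behaves the same way when the pyridin-3-yl of compound 1 is replaced by thiophen-2-yl or pyridin-2-yl, since the series so far shows this exchange on one heteroaryl only.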